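Swapping Fluoro for Isopropoxy in a Cytotoxicity Series

This account rests on a few compounds, and the source may have more. Where it says the series, first, only, none or still open, it means among the compounds named here.

Measured so far in an ADME assay on HEp-2 cells (Homo sapiens) for cytotoxicity, read by MTT assay, with a stated time of 72 h; on this read-out higher numbers stand for weaker inhibition and lower numbers for stronger inhibition:
- Compound 1 `COc1ccc(C2=C(c3cc(OC)c(OC)c(OC)c3)C(=O)C(OC(C)=O)C2)cc1F` gives < 1 ug/mL, which is a limit of the assay rather than a number.
- Compound 2 `COc1ccc(C2=C(c3cc(OC)c(OC)c(OC)c3)CC(O)C2=O)cc1[N+](=O)[O-]` gives > 100 ug/mL, also a limit.
- Compound 3 `COCOc1cc(C2=C(c3cc(OC)c(OC)c(OC)c3)C(=O)CC2O[SiH2]C(C)(C)C)ccc1OC` gives 12 ug/mL.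

Compound 1 sits at the strong end of what the assay can report, at the limit of < 1 ug/mL in this assay, at which 1 of the 3 values shown sits, so its true value stays hidden. Compound 4 `COc1ccc(C2=C(c3cc(OC)c(OC)c(OC)c3)C(=O)C(OC(C)=O)C2)cc1OC(C)C` differs from compound 1 in one place: isopropoxy in place of fluoro on an aromatic carbon. No measured pair separated by a single change is shown, so the size of this step cannot be read from the data. A step beyond the scatter, toward weaker inhibition, is expected; the step from compound 1 to compound 4 is estimated as an at least 3.0-fold higher number from compound 1 to compound 4 (0.47 log units; beyond the scatter). Compound 4 is expected to give about 3 ug/mL, between 0.5 ug/mL and 20 ug/mL.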

Compound 4, half-maximal inhibitory concentration: > 100 ug/mL
Compound 4 was reported as a limit; the forecaster's own chance of this, stated with the estimate: 25%; middle value at least 33-fold (1.52 log units) away from the limit.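

On this aromatic carbon, ortho to a methoxy group, putting isopropoxy in place of fluoro gives an at least 100-fold higher number from compound 1 to compound 4 (2.00 log units; beyond the scatter) in this assay. Among these compounds, this is the first single change that can be read, and it shows that this one position can take a compound from one end of the assay's range to the other. Compound 4 sits at a limit of the assay, so the full size of the step stays hidden: the limit of > 100 ug/mL in this assay, at which 2 of the 4 values shown sit.

As far as these compounds go, it remains open how ethoxy or an amine on this same carbon would read.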